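This account rests on a few compounds, and the source may have more. Where it says the series, first, only, none or still open, it means among the compounds named here.

The measured compounds:

Compound 1, `NCCOc1ccc([C@H]2CC[C@]3(CC2)OOC2(O3)C3CC4CC(C3)CC2C4)cc1`. In an ADME assay on microsomes from liver (Homo sapiens) for metabolic stability, read by LC-MS, tested at 1 uM (a lower number here means slower removal, a higher number faster removal of the compound), compound 1 gives < 7 mL.min-1.g-1, which is a limit of the assay rather than a number.

Compound 2, `NCCCOc1ccc([C@H]2CC[C@]3(CC2)OOC2(O3)C3CC4CC(C3)CC2C4)cc1`. In this assay compound 2 gives < 7 mL.min-1.g-1, again a limit.

Compound 3, `CC(C)(CN)Oc1ccc([C@H]2CC[C@]3(CC2)OOC2(O3)C3CC4CC(C3)CC2C4)cc1`. In this assay compound 3 gives < 7 mL.min-1.g-1, also a limit.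

All three values sit together at the same point, (the limit of < 7 mL.min-1.g-1 in this assay, at which 3 of the 3 values shown sit), so compound 3 stands level with compound 1 and compound 2 as far as the numbers can tell. None of the three steps between them can be sized: a step that the two limits leave unreadable from compound 1 to compound 2, a step that the two limits leave unreadable from compound 1 to compound 3 and a step that the two limits leave unreadable from compound 2 to compound 3 are each left unreadable by the two limits.

Compound 4, `c1cc([C@H]2CC[C@]3(CC2)OOC2(O3)C3CC4CC(C3)CC2C4)ccc1OCCCNC1CCOCC1`, has not yet been measured in this assay. It differs from compound 3 as follows: 3-((oxan-4-yl)amino)propyl in place of 1-(aminomethyl)-1-methylethyl on an oxygen on an aromatic ring. The three measured steps all alter the chain on the oxygen on the aromatic ring, and each is unreadable, so they give no measured direction for a change that brings in the 3-((oxan-4-yl)amino)propyl group. On that basis compound 4 is expected to remain close to the limit, with an expected step of an at least 1.1-fold higher number from compound 3 to compound 4 (0.05 log units; that floor lies within the scatter) that lies within the scatter. The estimate for compound 4 is 8 mL.min-1.g-1, in the range 4 mL.min-1.g-1 to 20 mL.min-1.g-1.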

Compound 4, intrinsic clearance in microsomes: 10 mL.min-1.g-1
Beside the measured number, compound 4's estimate is 1.3-fold (0.10 log units) below it; the range from low to high includes it.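

Compound 4 is the first of these compounds to give a number rather than a limit in this assay, which gives the change on the oxygen on an aromatic ring a lower bound for the first time: an at least 1.4-fold higher number from compound 3 to compound 4 (0.15 log units; that floor lies within the scatter), an at least 1.4-fold higher number from compound 2 to compound 4 (0.15 log units; that floor lies within the scatter) and an at least 1.4-fold higher number from compound 1 to compound 4 (0.15 log units; that floor lies within the scatter). Each of these bounds is only a floor within the scatter, so the result does not establish that the true step lies beyond the usual spread of repeated measurements. The oxan-4-yl group on the amine nitrogen of the chain is therefore the only change shown that yields a readable number, while the other three compounds remain at a limit: the limit of < 7 mL.min-1.g-1 in this assay, at which 3 of the 4 values shown sit.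

The steps among compound 1, compound 2 and compound 3 remain unreadable, and the compounds shown leave open whether a methyl or a cyclohexyl on that amine nitrogen would also give a number rather than a limit. Also open, as far as these compounds go, is how the oxan-4-yl group would read on the shorter 2-aminoethyl chain or on the 1-(aminomethyl)-1-methylethyl chain.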